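Dropping dimethylamino: compound 2 to compound 4

A few compounds are considered here, and "the series" means these few. Any claim that something is new, unique, unknown or untested is made for them only; others in the source may bear on it.

Results so far in a functional assay on HCT-116 cells (Homo sapiens) for cytotoxicity, read by MTT assay, with a stated time of 72 h (a lower number here means a stronger inhibitor, a higher number a weaker inhibitor), for the series
- compound 1 `Nc1ccc(Nc2c(C(=O)NCc3ccc(F)cc3)nc(Br)c3cccnc23)cc1` gives 10000 nM as a number
- compound 2 `CN(C)c1ccc(CNC(=O)c2nc(Br)c3cccnc3c2N[C@H]2CC[C@H](N)CC2)cc1` has "not determined" (no result reported) as its entry
- compound 3 `O=C(NCCCNc1c(C(=O)NCc2ccc(F)cc2)nc(Br)c2cccnc12)c1ccccc1` gives > 10000 nM as a limit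

Compound 2 has no number in this assay and so takes no place on the scale. The set holds the limit of > 10000 nM in this assay, at which 1 of the 3 values shown sits, and that value is a limit, not a number. The change to compound 4 `N[C@H]1CC[C@H](Nc2c(C(=O)NCc3ccccc3)nc(Br)c3cccnc23)CC1` is hydrogen in place of dimethylamino on an aromatic carbon and puts hydrogen in place of dimethylamino on an aromatic carbon. No step can be read without a number for compound 2, and none beyond the scatter is expected from this change in this assay for now. Among the compounds with values here, the estimate rests on compound 1 at 10000 nM as the only measured number. For compound 4 the expected value is 6000 nM with an estimated range from 1500 nM to 20000 nM in this series.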

Compound 4, half-maximal inhibitory concentration: 7000 nM
Estimate against measurement, compound 4: 1.2-fold (0.07 log units) below; low and high end bracket the measured number.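

Within the data shown here, compound 2 has no number in this assay and no step to compound 4 can be read. The compounds shown leave open what dropping dimethylamino does here, and nothing at hand bears on the value of compound 4.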